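Phenyl at the pyridine substituent position: expectation for compound 4

The source may report more compounds than this note shows. Statements on the series, on what has been measured and on what is new or still open speak of the compounds shown alone.

The series shares one core and varies a single aromatic carbon on the six-membered ring that holds one nitrogen. Compound 1 `CC1=NC(C)=C([N+](=O)[O-])C(c2ccccn2)/C1=C(/O)OCCc1ccccc1` carries hydrogen there, and in a functional assay (muscle tissue) with Cavia porcellus as the target (on this read-out lower numbers stand for stronger inhibition and higher numbers for weaker inhibition), compound 1 gives 639 nM. Compound 2 `CC1=NC(C)=C([N+](=O)[O-])C(c2cccc(C)n2)/C1=C(/O)OCCc1ccccc1` carries methyl, and in this assay compound 2 gives 9980 nM. Compound 3 `CC1=NC(C)=C([N+](=O)[O-])C(c2cccc([N+](=O)[O-])n2)/C1=C(/O)OCCc1ccccc1` carries nitro, and in this assay compound 3 gives 4740 nM, which places it second highest of the three numbers: the step of a 7.4-fold higher number from compound 1 to compound 3 (0.87 log units; beyond the scatter) is modest, while a 2.1-fold lower number from compound 2 to compound 3 (0.32 log units; beyond the scatter) is also modest, so compound 3 sits between the other two.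

Compound 4 `CC1=NC(C)=C([N+](=O)[O-])C(c2cccc(-c3ccccc3)n2)/C1=C(/O)OCCc1ccccc1` introduces the change (phenyl in place of nitro on an aromatic carbon). Going by the values given here, the steps that bear on it are a 16-fold higher number from compound 1 to compound 2 (1.19 log units; beyond the scatter), which is large, and a 7.4-fold higher number from compound 1 to compound 3 (0.87 log units; beyond the scatter), which is modest: every group that has replaced hydrogen at this carbon has raised the number beyond the scatter. Phenyl brings more heavy atoms than either methyl or nitro, so the expectation is a step upward from compound 3, likely at least as large as that seen for methyl. Compound 4 is therefore estimated at 15000 nM, with a range from 4000 nM to 60000 nM, meaning an expected step of a 3.2-fold higher number from compound 3 to compound 4 (0.50 log units; beyond the scatter).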

Compound 4, half-maximal inhibitory concentration: 8380 nM
Compound 4: the middle estimate sits 1.8-fold (0.25 log units) above what was measured, within the range that was stated.
By their numbers in this assay, from the lowest: compound 1; then compounds 3, 4 and 2 (each within the scatter of the next, the first and the last beyond it).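

In this assay, going by these compounds alone, the step of a 13-fold higher number from compound 1 to compound 4 (1.12 log units; beyond the scatter) is large, so phenyl, the first group here to bring a ring of its own to this carbon, joins methyl and nitro in leaving the number beyond the scatter above that of hydrogen. Replacing nitro with phenyl gives a 1.8-fold higher number from compound 3 to compound 4 (0.25 log units; within the scatter) and replacing methyl with phenyl gives a 1.2-fold lower number from compound 2 to compound 4 (0.08 log units; within the scatter); neither step separates phenyl from the smaller group it replaces, so the added ring brings no further change beyond the scatter. Across these compounds, what stands out at this carbon is the contrast between hydrogen and each of the three groups, and no group goes against it. Nothing available here explains why these groups give higher numbers than hydrogen.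

The compounds shown leave open whether a fluorine atom, a hydroxyl or an amine at this carbon would stay close to compound 1 or move as far as the three larger groups. They also leave open whether a carboxylic acid or a methoxy group on the added phenyl ring of compound 4 would change its number.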